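This account rests on a few compounds, and the source may have more. Where it says the series, first, only, none or still open, it means among the compounds named here.

Measured so far in an in vitro ADME assay on microsomes from liver (Homo sapiens) for metabolic stability; a higher number here means faster removal of the compound, a lower number slower removal:
- compound 1 `COc1ccc(-c2cc(-c3ccc(S(N)(=O)=O)cc3)cnc2N)cn1`: < 7 mL.min-1.g-1, a limit of the assay rather than a number
- compound 2 `COc1ccc(-c2cc(-c3ccc(S(=O)(=O)NC4CC4)cc3)cnc2N)cn1`: 15 mL.min-1.g-1
- compound 3 `COc1ccc(-c2cc(-c3ccc(C(F)(F)F)cc3)cnc2N)cn1`: 6.1 mL.min-1.g-1

Compound 3 holds the lowest of the two readable numbers in this assay. Its nearest neighbour is compound 2, with a 2.5-fold lower number from compound 2 to compound 3 (0.39 log units; beyond the scatter). The step that the limit leaves unreadable from compound 1 to compound 3 stays unreadable because of the limit of < 7 mL.min-1.g-1 in this assay, at which 1 of the 3 values shown sits, so compound 1 gives only a bound.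

Compound 4 `COc1ccc(-c2cc(-c3ccc(C(=O)N(C)C)cc3)cnc2N)cn1` is the next member and is not yet measured. Against compound 3 the change is dimethylcarbamoyl in place of trifluoromethyl on an aromatic carbon.

Going by the values given here, two measured steps bear on it. First, a 2.5-fold lower number from compound 2 to compound 3 (0.39 log units; beyond the scatter) shows that swapping a substituted sulfonamide for trifluoromethyl lowered clearance modestly; the reverse direction, putting a larger polar group back in that position, would be read as a modest rise. Second, an at least 2.1-fold higher number from compound 1 to compound 2 (0.33 log units; beyond the scatter) shows that adding carbon to the sulfonamide nitrogen raised clearance by at least a modest amount. Dimethylcarbamoyl likewise carries alkyl on a nitrogen, so a rise from compound 3 of about the size seen between compound 3 and compound 2 is the working expectation, though the gap to the parent sulfamoyl of compound 1 remains unreadable.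

Compound 4 is therefore expected near 11 mL.min-1.g-1, with a likely range from 5 mL.min-1.g-1 to 25 mL.min-1.g-1. The expected step is a 1.8-fold higher number from compound 3 to compound 4 (0.26 log units; within the scatter).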

Compound 4, intrinsic clearance in microsomes: 11.1 mL.min-1.g-1
Compound 4: middle estimate off by 1.0-fold (0.00 log units), on the low side; measured number inside the range.
By their numbers in this assay, from the lowest: compounds 3, 4 and 2 (each within the scatter of the next, the first and the last beyond it).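

In this assay, dimethylcarbamoyl on an aromatic carbon, para to a large group, is the one group shown at this place that lies within the scatter of both trifluoromethyl and cyclopropylsulfamoyl, with a 1.8-fold higher number from compound 3 to compound 4 (0.26 log units; within the scatter) and a 1.4-fold lower number from compound 2 to compound 4 (0.13 log units; within the scatter), although those two groups stand apart beyond the scatter, with a 2.5-fold lower number from compound 2 to compound 3 (0.39 log units; beyond the scatter).

Compound 1 gives < 7 mL.min-1.g-1, which is a limit of the assay and not a number.

The comparison with dimethylcarbamoyl therefore yields only a floor, an at least 1.5-fold higher number from compound 1 to compound 4 (0.20 log units; that floor lies within the scatter), and no step to compound 1 can be read as a size: the limit of < 7 mL.min-1.g-1 in this assay, at which 1 of the 4 values shown sits.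

Still open, from the compounds shown here alone, is whether the two methyl groups on the amide nitrogen matter for the number in this assay, a question that the unsubstituted carbamoyl group or a longer chain on that nitrogen would address. Also open, going by these compounds, is how a carboxylic acid or an amine at this place would read against compound 3 and compound 4.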